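A few compounds are considered here, and "the series" means these few. Any claim that something is new, unique, unknown or untested is made for them only; others in the source may bear on it.

Compound 1 `CN1C(=O)C(C2CC2)N(C)c2nc(Nc3ccc(S(N)(=O)=O)cc3)ncc21`: in an assay on Sf9 cells for inhibition of serine/threonine-protein kinase 4 (Homo sapiens), read by luminescence and ADP-Glo, with a stated time of 1 h, in the presence of a further agent that is not named here (on this read-out higher numbers stand for weaker inhibition and lower numbers for stronger inhibition), compound 1 gives 136 nM.
Compound 2 `CN1C(=O)C(c2ccccc2C(F)(F)F)N(C)c2nc(Nc3ccc(S(N)(=O)=O)cc3)ncc21`: in this assay compound 2 gives 56 nM.

Among these two numbers compound 2 stands lowest; its nearest neighbour is compound 1, and that gap is a 2.4-fold lower number from compound 1 to compound 2 (0.39 log units; beyond the scatter), which lies beyond the scatter. Compound 3 `CN1C(=O)C(c2ccccc2Br)N(C)c2nc(Nc3ccc(S(N)(=O)=O)cc3)ncc21` differs from compound 2 by bromo in place of trifluoromethyl on an aromatic carbon. Within the data shown here, no measured pair shows this exchange; the only measured step, a 2.4-fold lower number from compound 1 to compound 2 (0.39 log units; beyond the scatter), concerns a different part of the molecule, the swap of cyclopropyl for an aromatic ring, and so says little about what a different group on that ring will do. With no direct guide, no step beyond the scatter is expected in this assay. Compound 3 is therefore estimated at 60 nM, within a range of 25 nM to 150 nM. That estimate corresponds to a step of a 1.1-fold higher number from compound 2 to compound 3 (0.03 log units; within the scatter).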

Compound 3, half-maximal inhibitory concentration: 57 nM
Estimate against measurement, compound 3: 1.1-fold (0.02 log units) above; low and high end bracket the measured number.
By their numbers in this assay, from the lowest: compounds 2 and 3 (each within the scatter of the next); then compound 1.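

In this assay bromo and trifluoromethyl on this aromatic carbon cannot be told apart: the exchange gives a 1.0-fold higher number from compound 2 to compound 3 (0.01 log units; within the scatter) even though bromo has one heavy atom and trifluoromethyl has four. The step of a 2.4-fold lower number from compound 1 to compound 3 (0.38 log units; beyond the scatter) shows that the stronger inhibition seen against the cyclopropyl compound is not tied to trifluoromethyl, since it holds with bromo as well. Nothing measured here explains why these two groups give matching numbers.

Still open is whether the ring needs a group at this place at all, since plain phenyl is not among the compounds shown. Also open, going by these compounds, is whether an amine, a carboxylic acid or a methoxy group on this carbon would keep the number at this level.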